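The source may report more compounds than this note shows. Statements on the series, on what has been measured and on what is new or still open speak of the compounds shown alone.

Measured in a physicochemical assay for metabolic stability, read by HPLC and mass spectrometry, in phosphate buffer, at 37 degrees C, at pH 7.4; a lower number here means that the compound disappears faster, a higher number that the compound lasts longer:
- Compound 1 `CC(C)(O/N=C(\C(=O)N[C@@H]1C(=O)N(S(=O)(=O)O)[C@@H]1Cn1ccnn1)c1csc(N)n1)C(=O)O`: 257 h.
- Compound 2 `CC(C)(O/N=C(\C(=O)N[C@@H]1C(=O)N(S(=O)(=O)O)[C@@H]1CN1C[C@@H](CN)OC1=O)c1csc(N)n1)C(=O)O`: > 37 h.

Going by these compounds, the value of compound 2 is a limit and not a number, so its place on the scale stays open. Compound 3 `CC(C)(O/N=C(\C(=O)N[C@@H]1C(=O)N(S(=O)(=O)O)[C@@H]1CN1C[C@H](CN)OC1=O)c1csc(N)n1)C(=O)O` differs from compound 2 as follows: the two compounds have the same atoms and bonds and differ only in configuration as drawn: 1 of 4 stereo elements differ; a stereocentre at a saturated ring carbon is drawn R in compound 2 and S in compound 3. Among the measured compounds shown here, the only measured step, a step that the limit leaves unreadable from compound 1 to compound 2, exchanges a group rather than a configuration, and its size cannot be read, so it offers no size to carry over. No change beyond the scatter is therefore expected, and the estimated step is a step that the limit leaves unreadable from compound 2 to compound 3. For compound 3, the expected half-life in this assay is 80 h, with an estimated range of 35 h to 260 h.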

Compound 3, half-life: > 37 h
Compound 3 ended at the assay's limit (the forecaster's own chance of this, stated with the estimate: 55%); the middle value is on the limit's open side.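

In this assay, no new step can be read from compound 3 to compound 1 or compound 2: the limit of > 37 h in this assay, at which 2 of the 3 values shown sit.

The compounds shown leave open how long compound 2 and compound 3 actually last, and whether their half-lives differ at all: the fact that compounds 2 and 3 differ only in the configuration as drawn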